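The source may hold more compounds than are shown below. What is called first, only, known or untested is meant among the compounds shown, and "the series" means these compounds.

In a physicochemical assay for solubility, in phosphate buffer, measured as kinetic solubility, at pH 7.4 (a lower number here means a less soluble compound, a higher number a more soluble compound), two compounds have been measured so far. Compound 1 `COc1ccc(-c2cc([C@@H](O)C[C@@H](O)CCc3ccc(Cl)cc3)no2)cc1` gives 12000 nM, and compound 2 `COc1ccc(CC[C@H](O)C[C@H](O)c2cc(-c3ccc(OC)cc3)on2)cc1` gives 12000 nM, which places compound 2 level with compound 1. The next structure is compound 3 `COc1ccc(CC[C@H](O)C[C@H](O)c2cc(-c3ccccc3)on2)cc1`, which differs from compound 2 as follows: hydrogen in place of methoxy on an aromatic carbon. In words, this is hydrogen in place of methoxy on an aromatic carbon, and the same difference reads 4-methoxyphenyl to phenyl. Among the compounds with values here, only one measured step bears on this change, namely no change at the digits printed from compound 1 to compound 2 (within the scatter), where methoxy took the place of chloro on an aromatic carbon. That step is an imperfect guide, since it swapped one group for another on a different aromatic ring, whereas here a group is lost and only hydrogen remains. Within the data shown here, still, the sole evidence shows no movement, so no shift beyond the scatter is expected in this assay. The expected size of the change is no change at the digits printed from compound 2 to compound 3 (within the scatter). For compound 3 the estimate is 12000 nM, with an expected range from 6000 nM to 25000 nM.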

Compound 3, solubility: 25000 nM
For compound 3 the middle estimate is 2.1-fold (0.32 log units) below the measured one; the range from low to high includes it.
By their numbers in this assay, from the lowest: compounds 1 and 2 (each within the scatter of the next); then compound 3.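

In this assay, the change from 4-methoxyphenyl to phenyl gives a 2.1-fold higher number from compound 2 to compound 3 (0.32 log units; beyond the scatter), so the loss of methoxy from this place, para to a large group on a six-membered aromatic ring of carbon only, registers in this read-out. The earlier step, no change at the digits printed from compound 1 to compound 2 (within the scatter), exchanged chloro for methoxy on an aromatic carbon of the other aryl group and stayed within the scatter, so compound 3 supplies the first movement beyond the scatter among the compounds shown, and that movement is modest. Nothing available here bears on why removing the methoxy gives the higher number.

The compounds shown leave open whether the same exchange of methoxy for hydrogen on the other aromatic ring, where compound 2 also carries a methoxy, would give a comparable step in this assay. They also leave open how a different group at the position that is bare in compound 3, such as an amine or a carboxylic acid, would compare with hydrogen and methoxy.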